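Chloro for fluoro on the sulfonyl ring, low cytotoxicity

A few compounds are considered here, and "the series" means these few. Any claim that something is new, unique, unknown or untested is made for them only; others in the source may bear on it.

Compound 1, `O=C1/C(=C/c2cccnc2)CN(S(=O)(=O)c2ccc(F)cc2)C/C1=C\c1ccccc1F`, in an ADME assay on L02 cells (Homo sapiens) for cytotoxicity, read by MTT assay, with a stated time of 24 h (on this read-out lower numbers stand for stronger inhibition and higher numbers for weaker inhibition), gives 15600 nM.
Compound 2, `O=C1/C(=C/c2cccnc2)CN(S(=O)(=O)c2ccc(Cl)cc2)C/C1=C\c1ccccc1F`, in this assay gives > 20000 nM, a limit of the assay rather than a number.
Compound 3, `O=C1/C(=C/c2cccnc2)CN(S(=O)(=O)c2ccc(F)cc2)C/C1=C\c1ccccc1C(F)(F)F`, in this assay gives 16100 nM.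

Compound 1 and compound 2 differ by chloro in place of fluoro on an aromatic carbon; this gave an at least 1.2-fold higher number from compound 1 to compound 2 (0.10 log units; that floor lies within the scatter), with compound 2 sitting at the limit of > 20000 nM in this assay, at which 1 of the 3 values shown sits. The two cores differ by trifluoromethyl in place of fluoro on an aromatic carbon, which gave a 1.0-fold higher number from compound 1 to compound 3 (0.01 log units; within the scatter). Compound 4, `O=C1/C(=C/c2cccnc2)CN(S(=O)(=O)c2ccc(Cl)cc2)C/C1=C\c1ccccc1C(F)(F)F`, not yet measured, differs from compound 3 by chloro in place of fluoro on an aromatic carbon, the same change. For compound 4 the expected step is a 1.4-fold higher number from compound 3 to compound 4 (0.14 log units; within the scatter), resting on the measured step of an at least 1.2-fold higher number from compound 1 to compound 2 (0.10 log units; that floor lies within the scatter). Compound 4 is therefore expected to give 22000 nM in this assay, between 14000 nM and 40000 nM, quite possibly reported only as a limit.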

Compound 4, half-maximal inhibitory concentration: 11900 nM
Compound 4: the middle estimate sits 1.8-fold (0.27 log units) above what was measured; measured number outside the range, below it.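

On the core of compound 3, chloro in place of fluoro gave a 1.4-fold lower number from compound 3 to compound 4 (0.13 log units; within the scatter) in this assay. Set beside the same change on the core of compound 1, this does not show whether the change carries over unchanged from one core to the other: the same change on two cores in this assay, an at least 1.2-fold higher number (0.10 log units; that floor lies within the scatter) from compound 1 to compound 2 and a 1.4-fold lower number (0.13 log units; within the scatter) from compound 3 to compound 4; the limit leaves it open whether they differ Trifluoromethyl in place of fluoro, read with chloro on the sulfonyl ring, gave an at least 1.6-fold lower number from compound 2 to compound 4 (0.22 log units; that floor lies within the scatter), and the comparison with the fluoro pair stays equally unsettled: the same change on two cores in this assay, a 1.0-fold higher number (0.01 log units; within the scatter) from compound 1 to compound 3 and an at least 1.6-fold lower number (0.22 log units; that floor lies within the scatter) from compound 2 to compound 4; the limit leaves it open whether they differ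

From the compounds shown here alone, the size of the step from compound 1 to compound 2 remains open, as compound 2 stands only at a limit. Also open, going by these compounds, is how an amine or a carboxylic acid in place of the fluoro or chloro would read in this assay.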